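This account rests on a few compounds, and the source may have more. Where it says the series, first, only, none or still open, it means among the compounds named here.

compound 1 `O=C(Nc1ccc2sc(-c3ccccc3)nc2c1)N1CCCCC1` gives 62%
compound 2 `O=C(Nc1ccc2sc(-c3ccc(F)c(F)c3)nc2c1)N1CCCC1` gives 66%
compound 3 `O=C(Nc1ccc2oc(-c3ccccc3)nc2c1)N1CCCCC1` gives 77%

All three values come from an ADME assay on microsomes from liver (Homo sapiens) for metabolic stability, read by mass spectrometry, using NADPH, with a stated time of 60 min, tested at 1.5 uM (on this read-out higher numbers stand for a more stable compound and lower numbers for a less stable compound), and can be compared directly. Compound 1 at 62% lies within the usual scatter of compound 2 at 66% and the two cannot be told apart. Compound 3 at 77% stands higher than compound 1 by more than the scatter.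

Compound 4 `O=C(Nc1ccc2sc(-c3ccccc3)nc2c1)c1ccccc1` has not yet been measured in this assay and keeps the core of compound 1. The difference between the two is phenyl in place of piperidin-1-yl on a carbonyl carbon with phenyl in place of piperidin-1-yl on a carbonyl carbon. The other neighbour of that carbon is an amide-type nitrogen.

Within the data shown here, no measured pair shows this change on its own, so the data give no direct size for it. With no such guide, no step beyond the scatter is expected in either direction. An estimated a number 3 percentage points higher from compound 1 to compound 4 (within the scatter) would stay within the scatter. For compound 4 the expected value is 65% and the estimated range from 45% to 85% is deliberately wide.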

Compound 4, percent of the compound remaining: 53%
The estimate for compound 4 lay 12 percentage points above the measured number, within the range that was stated.
By their numbers in this assay, from the lowest: compounds 4, 1 and 2 (each within the scatter of the next, the first and the last beyond it); then compound 3.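

In this assay, among these compounds, this is the first pair of compounds that differ in one place, so it gives a direct size for a change on this carbonyl carbon: phenyl in place of piperidin-1-yl comes with a number 9 percentage points lower from compound 1 to compound 4 (within the scatter). At this place, whose other neighbour is an amide-type nitrogen, exchanging a six-membered non-aromatic ring holding one hetero atom for a six-membered aromatic ring of carbon only, with the same count of heavy atoms, therefore does not separate the two compounds on this read-out. Nothing among the data shown bears on the reason for this outcome, so no cause can be offered for it.

As far as these compounds go, what other groups on this carbon would do remains open, for example a morpholine ring, a dimethylamino group or a longer alkyl chain, and so does the effect of a carboxylic acid on the new phenyl ring. A single pair also cannot say whether the same exchange would give a step of similar size on a core other than that of compound 1.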